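This account rests on a few compounds, and the source may have more. Where it says the series, first, only, none or still open, it means among the compounds named here.

Working notes on the series.

Of the compounds shown here, two carry numbers so far. Compound 1, `CCn1cnc(Nc2nc(N[C@@H](C)c3ccc(F)cn3)nc3cccc(F)c23)c1`, gives 280 nM in an assay on isolated protein for inhibition of G protein-coupled receptor kinase 6 (Homo sapiens), read by scintillation counting, radiometric assay and 33P incorporation, with a stated time of 80 min, in the presence of a further agent that is not named here; a lower number here means a stronger inhibitor, a higher number a weaker inhibitor. Compound 2, `CCc1cc(Nc2nc(N[C@@H](C)c3ccc(F)cc3)nc3ccc(OC)cc23)n[nH]1`, gives 140 nM in this assay. The two numbers lie within the usual scatter of each other, so neither compound can be called the stronger inhibitor; compound 1 simply carries the higher of the two numbers shown, and compound 2 differs from it in several places at once, so nothing about a single change can be read from that pair.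

Compound 3, `CCOc1ccc(Nc2nc(N[C@@H](C)c3ccc(F)cn3)nc3cccc(F)c23)cn1`, has not yet been measured in this assay. Against compound 1 the change is a group of 9 heavy atoms (7 carbon, 1 nitrogen, 1 oxygen; one six-membered aromatic ring with 1 hetero atom) in place of a group of 7 heavy atoms (5 carbon, 2 nitrogen; one five-membered aromatic ring with 2 hetero atoms), on a nitrogen on an aromatic ring. Among the compounds with values here, no measured pair tells what such an exchange does, so there is no step to lean on. Without such a step the expectation for compound 3 is no change beyond the scatter, and the step from compound 1 to compound 3 is estimated as a 1.1-fold higher number from compound 1 to compound 3 (0.03 log units; within the scatter). Compound 3 is accordingly expected to give about 300 nM in this assay, with a range from 80 nM to 1200 nM that reflects the absence of any matched pair for this change.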

Compound 3, half-maximal inhibitory concentration: > 10000 nM
Compound 3: only a limit was reported; the forecaster's own chance of this, stated with the estimate: 5%; middle value at least 33-fold (1.52 log units) away from the limit.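

Within the data shown here, the exchange on this nitrogen on an aromatic ring, from the five-membered aromatic ring with 2 hetero atoms to 6-ethoxypyridin-3-yl, gives an at least 35-fold higher number from compound 1 to compound 3 (1.55 log units; beyond the scatter) in this assay, and this is the first single-place step. It shows that this position is not indifferent to what it carries: with the rest of compound 1 held fixed, this one exchange moves the result far beyond the scatter, which the earlier pair, differing in several places at once, could not show. The step rests on a limit of the assay and not on a number, so its full size stays unread: the limit of > 10000 nM in this assay, at which 1 of the 3 values shown sits.

The compounds shown leave open whether the step belongs to the six-membered aromatic ring with 1 hetero atom or to the ethoxy group on it; a pyridin-3-yl carrying a methoxy group, an amine or no group at all in place of the ethoxy would separate the two. Also open, from the compounds shown here alone, is whether the same exchange has a similar effect on the core of compound 2, which differs from compound 1 in several places.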